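This account rests on a few compounds, and the source may have more. Where it says the series, first, only, none or still open, it means among the compounds named here.

Compound 2 `CC(C)(C)N1C(=O)NC2(CSC3=C2C(=O)c2ccccc2C3=O)C1=O` gives 331 nM in a functional assay on MCF7 cells (Homo sapiens) for inhibition (on this read-out higher numbers stand for weaker inhibition and lower numbers for stronger inhibition), the highest of the two single numbers reported. Among the compounds with values here, its nearest neighbour, compound 1 `CCCN1C(=O)NC2(CSC3=C2C(=O)c2ccccc2C3=O)C1=O`, gives 104 nM, and the change a 3.2-fold higher number from compound 1 to compound 2 (0.50 log units; beyond the scatter) is the only one-place step measured so far. Compound 3 `NCCN1C(=O)NC2(CSC3=C2C(=O)c2ccccc2C3=O)C1=O`, which carries an aminoethyl chain, returns 22 nM; 20 nM; 31 nM (3 entries), numbers well under those of compound 2, as the several entries of compound 3 in this assay, 22 nM; 20 nM; 31 nM (3 entries) shows. Compound 4 `NCCCCN1C(=O)NC2(CSC3=C2C(=O)c2ccccc2C3=O)C1=O` differs from compound 2 by 4-aminobutyl in place of tert-butyl on an amide-type nitrogen in a ring. Within the data shown here, no measured step covers this exact exchange; the branched-to-straight change is modest in the one step measured, while the aminoalkyl compound 3 sits far lower. The step expected here, an 8.3-fold lower number from compound 2 to compound 4 (0.92 log units; beyond the scatter), therefore runs toward a lower number. Compound 4 is estimated at 40 nM, within a range from 12 nM to 130 nM.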

Compound 4, half-maximal inhibitory concentration: 35 nM
The estimate for compound 4 lay 1.1-fold (0.06 log units) above the measured number; measured number inside the range.
By their numbers in this assay, from the lowest: compound 4; then compound 1; then compound 2.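

On this nitrogen, 4-aminobutyl in place of tert-butyl gives a 9.5-fold lower number from compound 2 to compound 4 (0.98 log units; beyond the scatter) in this assay. The comparison with the unbranched propyl chain shows that the branched tert-butyl is not the whole story, as adding the aminomethyl end alone gives a 3.0-fold lower number from compound 1 to compound 4 (0.47 log units; beyond the scatter). An amine-ended chain now stands at two lengths, and compound 4 lies in the same general range as the aminoethyl compound 3: the several entries of compound 3 in this assay, 22 nM; 20 nM; 31 nM (3 entries)

The compounds shown leave open whether a hydroxyl at the chain end would give numbers like those of the amine. They also leave open whether a dimethylamino end or a longer chain would keep them this low.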